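The compounds below may be only part of what the source reports. "The series", "measured", "known", "first", "only" and "open" are said of these compounds alone.

Measured so far in an assay on isolated protein for inhibition of histone deacetylase 4 (Homo sapiens), with a stated time of 1 h; on this read-out higher numbers stand for weaker inhibition and lower numbers for stronger inhibition:
compound 1 `Cc1ccc(NC(=O)COc2ccc3cc(/C=C4/SC(=O)NC4=O)ccc3c2)cc1` gives 1700 nM
compound 2 `COc1cccc(NC(=O)COc2ccc3cc(/C=C4/SC(=O)NC4=O)ccc3c2)c1` gives 1600 nM
compound 3 `O=C(COc1ccc2cc(/C=C3/SC(=O)NC3=O)ccc2c1)Nc1ccccn1` gives 17000 nM

Compound 3 stands highest of the three: a 10-fold higher number from compound 1 to compound 3 (1.00 log units; beyond the scatter) and an 11-fold higher number from compound 2 to compound 3 (1.03 log units; beyond the scatter) are both beyond the scatter, whereas a 1.1-fold lower number from compound 1 to compound 2 (0.03 log units; within the scatter) lies within it. Compound 4 `O=C(COc1ccc2cc(/C=C3/SC(=O)NC3=O)ccc2c1)Nc1cccc(F)n1` keeps the core of compound 3 and carries fluoro in place of hydrogen on an aromatic carbon. Among the compounds with values here, no measured step alters a substituent on the pyridin-2-yl group, so none bears directly on this change; the one substituent-level comparison available, a 1.1-fold lower number from compound 1 to compound 2 (0.03 log units; within the scatter), stayed within the scatter, and compound 4 retains the pyridin-2-yl group of compound 3, the compound with the high number. A step no larger than the scatter is therefore expected in this assay, a 1.2-fold lower number from compound 3 to compound 4 (0.08 log units; within the scatter). Compound 4 is estimated at 14000 nM, with a range of 5000 nM to 40000 nM.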

Compound 4, half-maximal inhibitory concentration: 840 nM
Compound 4: the middle estimate sits 17-fold (1.22 log units) above what was measured; the whole stated range lies above it.
By their numbers in this assay, from the lowest: compounds 4, 2 and 1 (each within the scatter of the next, the first and the last beyond it); then compound 3.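

In this assay, a single fluoro next to the ring nitrogen of the pyridin-2-yl group has a large effect, a 20-fold lower number from compound 3 to compound 4 (1.31 log units; beyond the scatter), so this position is far more sensitive than the earlier substituent change suggested. The 6-fluoropyridin-2-yl group also closes the gap to the earlier anilides: a 1.9-fold lower number from compound 2 to compound 4 (0.28 log units; within the scatter), and a 2.0-fold lower number from compound 1 to compound 4 (0.31 log units; beyond the scatter). No available measurement accounts for the gain.

Open, from the compounds shown here alone, is whether the gain belongs to fluoro itself or would also come with chloro, methyl or an amine at the same place. Also open, going by these compounds, is how fluoro would act elsewhere on the ring.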